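The compounds below may be only part of what the source reports. "The series", "measured", "known", "first", "only" and "open" are said of these compounds alone.

Working notes on the series. Among the measured compounds shown here, compound 2 `CCCC(=O)Nc1ccc(-c2cc3n(Cc4ccccc4F)cc(C(=O)OC(CC)CC)c(=O)n3c2CN(C)Cc2ccccc2)cc1` is one of two compounds measured in an assay on HEK293 cells for binding affinity to Gonadotropin-releasing hormone receptor (Homo sapiens), read by radioligand binding; on this read-out lower numbers stand for stronger inhibition and higher numbers for weaker inhibition. Compound 1 `CCC(CC)OC(=O)c1cn(Cc2ccccc2F)c2cc(-c3ccc(NC(C)=O)cc3)c(CN(C)Cc3ccccc3)n2c1=O` gives 4 nM in this assay, and compound 2 gives 3.8 nM; this leaves compound 2 with the lowest of the two numbers, though the gap to compound 1 is within the scatter. For the measured compounds named here, the only measured step, a 1.1-fold lower number from compound 1 to compound 2 (0.02 log units; within the scatter), concerns the amide end of the molecule, where ethyl replaced hydrogen on a saturated chain carbon bound to a carbonyl carbon.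

Compound 3 `CCCC(=O)Nc1ccc(-c2cc3n(Cc4ccccc4F)cc(C(=O)OC(CC)CC)c(=O)n3c2CN(C)C)cc1` is not yet measured. It differs from compound 2 by hydrogen in place of phenyl on a saturated chain carbon bound to an amine nitrogen; cut one bond further out, the change reads benzyl to methyl, benzyl(methyl)amino to dimethylamino. Going by the values given here, no measured step touches this place. The recorded step from compound 1 to compound 2 sits elsewhere and was within the scatter, so it gives no guide to the size or direction of the present change. The expectation for compound 3, lacking direct evidence, is a step of a 3.2-fold higher number from compound 2 to compound 3 (0.50 log units; beyond the scatter) toward a higher number. Compound 3 is therefore estimated at 12 nM, with a range from 3 nM to 50 nM.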

Compound 3, inhibition constant: 130 nM
Estimate against measurement, compound 3: 11-fold (1.03 log units) below; measured number outside the range, above it.
By their numbers in this assay, from the lowest: compounds 2 and 1 (each within the scatter of the next); then compound 3.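

In this assay, among the compounds shown here, replacing benzyl(methyl)amino with dimethylamino gives a 34-fold higher number from compound 2 to compound 3 (1.53 log units; beyond the scatter) and is the first single change to move the number beyond the scatter. The change at the amide end, by contrast, gives a 1.1-fold lower number from compound 1 to compound 2 (0.02 log units; within the scatter) and stays within the scatter, so among these three compounds the benzyl group on the amine nitrogen is the place where the read-out responds strongly, while the butanamide and acetamide ends cannot be told apart. Nothing recorded for the series accounts for the size of this step.

The compounds shown leave open whether a chain intermediate between methyl and benzyl on the amine nitrogen, such as ethyl or n-butyl, recovers part of the number, and whether a saturated ring, as in cyclohexylmethyl, can stand in for the phenyl of the benzyl group. Also open, as far as these compounds go, is how far compound 2 at 3.8 nM can be matched or passed with a fluoro or methoxy group on that phenyl, or with pyridylmethyl in place of benzyl.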